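The source may hold more compounds than are shown below. What is called first, only, known or untested is meant among the compounds shown, and "the series" means these compounds.

Measured compounds:

compound 1, `Cc1ccc(/C=C/c2ccc(N(C)C)cc2)cc1`
compound 2, `Fc1ccc(/N=C/c2ccccc2Cl)cc1Cl`
compound 3, `Cc1ccc(/C=C/c2ccccc2F)cc1`

In a functional assay on MOLT-4 cells (Homo sapiens), read by cell counting, with a stated time of 72 h (on this read-out higher numbers stand for weaker inhibition and lower numbers for stronger inhibition), compound 1 gives only a limit, > 200 ug/mL, and no number. In this assay compound 2 gives 3.9 ug/mL. In this assay compound 3 gives 30 ug/mL, the highest of the two numbers obtained; the gap to compound 2 lies beyond the scatter.

Compound 4, `Fc1ccc(/C=C/c2ccccc2F)cc1`, is not yet measured. It differs from compound 3 by fluoro in place of methyl on an aromatic carbon. For the measured compounds named here, no measured pair shows this exchange. In this assay a step from compound 3 to compound 4 of no more than the scatter is expected, in either direction. Compound 4 is estimated at 30 ug/mL, within 10 ug/mL to 90 ug/mL, corresponding to no change at the digits printed from compound 3 to compound 4 (within the scatter).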

Compound 4, half-maximal inhibitory concentration: 61 ug/mL
Beside the measured number, compound 4's estimate is 2.0-fold (0.31 log units) below it; the measured number falls inside the stated range.
By their numbers in this assay, from the lowest: compound 2; then compound 3; then compound 4. At a limit, above all of these: compound 1.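

In this assay, for the compounds shown here, fluoro in place of methyl on an aromatic carbon, para to a group of 9 heavy atoms, gives a 2.0-fold higher number from compound 3 to compound 4 (0.31 log units; beyond the scatter) as the first one-place comparison. This position therefore responds to the exchange, modestly, and a measurable number survives without the methyl. Nothing shown accounts for the direction of this step.

Going by these compounds, whether an amine or a carboxylic acid in this place would shift the number further stays open. So does whether the same exchange gives a similar step on another core.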